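A few compounds are considered here, and "the series" means these few. Any claim that something is new, unique, unknown or untested is made for them only; others in the source may bear on it.

For the measured compounds named here, in a functional assay on MCF7 cells (Homo sapiens) for inhibition, in the absence of a further agent (on this read-out higher numbers stand for weaker inhibition and lower numbers for stronger inhibition), compound 1 `Nc1ccc(-c2cc(=O)c3c(N)c(F)cc(F)c3o2)cc1F` gives 1.2 nM, the lowest of the three numbers so far. Compound 3 `Nc1c(F)cc(-c2cc(=O)c3c(N)c(F)cc(F)c3o2)cc1F` gives 4 nM, and compound 2 `Cc1ccc(N)c2c(=O)cc(-c3ccc(N)c(F)c3)oc12` gives 15 nM. Compound 4 `Nc1ccc(-c2cc(=O)c3c(N)c(F)cc(F)c3o2)cc1` has not yet been measured. It differs from compound 1 by hydrogen in place of fluoro on an aromatic carbon, ortho to an amino group: hydrogen in place of fluoro on an aromatic carbon. Going by the values given here, one measured step bears on this change, the modest 3.3-fold higher number from compound 1 to compound 3 (0.52 log units; beyond the scatter), with fluoro in place of hydrogen on an aromatic carbon. That step adds a fluoro rather than removing one, so it does not settle the direction. Compound 1, at 1.2 nM, holds the lowest number, which leaves a modest step of similar size towards a higher number as the expectation. In this assay the expected step is a 3.3-fold higher number from compound 1 to compound 4 (0.52 log units; beyond the scatter). Compound 4 is estimated at 4 nM, with an expected range of 1.2 nM to 15 nM.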

Compound 4, half-maximal inhibitory concentration: 6 nM
Estimate against measurement, compound 4: 1.5-fold (0.18 log units) below; measured number inside the range.
By their numbers in this assay, from the lowest: compound 1; then compounds 3 and 4 (each within the scatter of the next); then compound 2.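

Replacing the fluoro ortho to the amino group with hydrogen gives a 5.0-fold higher number from compound 1 to compound 4 (0.70 log units; beyond the scatter), so this position does not tolerate the change without a shift beyond the scatter. Together with a 3.3-fold higher number from compound 1 to compound 3 (0.52 log units; beyond the scatter), where a further fluoro enters, this means that both single changes shown from compound 1 lead to a higher number, one removing a fluoro and the other adding one. Nothing available accounts for this step. The compounds shown leave open how a chloro or a methoxy group at this position would compare with the fluoro of compound 1.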